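The source may hold more compounds than are shown below. What is called first, only, known or untested is meant among the compounds shown, and "the series" means these compounds.

Compound 3 `CCCSc1nc(N/N=C(\C)c2ccc(O)cc2)c2nnn(Cc3ccccc3)c2n1` gives 16700 nM in a functional assay on MGC-803 cells (Homo sapiens) for antiproliferative activity, read by MTT assay, with a stated time of 72 h (a higher number here means a weaker inhibitor, a lower number a stronger inhibitor), the second highest of the three numbers measured. Compound 2 `CCCSc1nc(N/N=C/c2cccnc2)c2nnn(Cc3ccccc3)c2n1` gives 38100 nM, and compound 1 `CCCSc1nc(N/N=C(\C)c2ccccc2O)c2nnn(Cc3ccco3)c2n1` gives 4760 nM. For the measured compounds named here, the one measured step, a 2.3-fold lower number from compound 2 to compound 3 (0.36 log units; beyond the scatter), concerns a different change and does not bear on the present one. Compound 4 `CCCSc1nc(N/N=C(\C)c2ccccc2O)c2nnn(Cc3ccccc3)c2n1` differs from compound 3 by 2-hydroxyphenyl in place of 4-hydroxyphenyl on a carbon with a double bond to nitrogen. Compound 1 already carries 2-hydroxyphenyl but differs from compound 4 elsewhere, so its value only hints at the direction. Compound 4 is therefore expected to give a lower number than compound 3, by a 2.1-fold lower number from compound 3 to compound 4 (0.32 log units; beyond the scatter). The estimate for compound 4 is 8000 nM, within a range from 3000 nM to 22000 nM.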

Compound 4, half-maximal inhibitory concentration: 2310 nM
Beside the measured number, compound 4's estimate is 3.5-fold (0.54 log units) above it; the measured number lies below the stated range.
By their numbers in this assay, from the lowest: compound 4; then compound 1; then compound 3; then compound 2.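

In this assay, with the same atoms joined differently, 2-hydroxyphenyl in place of 4-hydroxyphenyl on a carbon with a double bond to nitrogen gives a 7.2-fold lower number from compound 3 to compound 4 (0.86 log units; beyond the scatter), so the place of the hydroxyl on this ring alone changes the number. That step also accounts for much of a 16-fold lower number from compound 2 to compound 4 (1.22 log units; beyond the scatter), which exceeds the earlier 2.3-fold lower number from compound 2 to compound 3 (0.36 log units; beyond the scatter), while with 2-hydroxyphenyl held constant, phenyl in place of furan-2-yl gives the smaller 2.1-fold lower number from compound 1 to compound 4 (0.31 log units; beyond the scatter). No measurement here accounts for these differences. From the compounds shown here alone, whether an amine or a methoxy group could replace the hydroxyl of 2-hydroxyphenyl and keep this level stays open.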